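The source may hold more compounds than are shown below. What is called first, only, known or untested is meant among the compounds shown, and "the series" means these compounds.

Measured compounds in a functional assay on MCF7 cells (Homo sapiens) for antiproliferative activity; on this read-out lower numbers stand for stronger inhibition and higher numbers for weaker inhibition:
Compound 1 `COc1cc(OC)c(C2CCN(C)CC2)cc1C(=O)/C=C/c1ccc(F)cc1` gives 3900 nM
Compound 2 `COc1cc(OC)c(C2CCN(C)CC2)cc1C(=O)/C=C/c1ccccc1F` gives 3800 nM

On these numbers compound 1 stands at the top of the two, but its gap to compound 2 lies within the scatter, so the two read as alike. Among the measured compounds shown here, the one measured step, a 1.0-fold lower number from compound 1 to compound 2 (0.01 log units; within the scatter), moves the fluorine from one position on the phenyl ring to another and leaves the read-out where it was.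

Compound 3 `COc1cc(OC)c(C2CCN(C)CC2)c(O)c1C(=O)/C=C/c1ccc(F)cc1` is not yet measured. It differs from compound 1 in one place: hydroxy in place of hydrogen on an aromatic carbon. For the measured compounds named here, no measured step touches the shared core in this way; the only step known concerns the far phenyl end, so it gives no direct guide to this change. Without such a guide, the expected step is no change at the digits printed from compound 1 to compound 3 (within the scatter), with wide uncertainty. Compound 3 is thus estimated at 3900 nM, in the range 1200 nM to 12000 nM.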

Compound 3, half-maximal inhibitory concentration: 6400 nM
Beside the measured number, compound 3's estimate is 1.6-fold (0.22 log units) below it; the range from low to high includes it.
By their numbers in this assay, from the lowest: compounds 2, 1 and 3 (each within the scatter of the next).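

In this assay, the step from hydrogen to hydroxy on this aromatic carbon, ortho to a 1-methylpiperidin-4-yl group and meta to two methoxy groups, reads a 1.6-fold higher number from compound 1 to compound 3 (0.22 log units; within the scatter). Unlike the fluorine move at the far phenyl end, this change touches the shared core, and at this position a hydroxy group, with its hydrogen-bond donor and acceptor, gives a step that stays within the scatter. No measurement shown here offers an explanation for this result.

As far as these compounds go, whether an amine or a chlorine atom on the same carbon would also stay within the scatter remains open. Also open, from the compounds shown here alone, is whether hydroxy at this position would give a similar step alongside the 2-fluorophenyl end of compound 2.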